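A few compounds are considered here, and "the series" means these few. Any claim that something is new, unique, unknown or untested is made for them only; others in the source may bear on it.

Of the compounds shown here, two sharing one core have been measured so far. In a functional assay on A-375 cells (Homo sapiens) for cytotoxicity, read by MTT assay, with a stated time of 72 h (on this read-out lower numbers stand for stronger inhibition and higher numbers for weaker inhibition), compound 1 (`O=C1c2c[n+]([O-])c3ccccc3c2C(=O)c2c1c1ccccc1n2Cc1cn(C[C@H](O)CO)nn1`) gives 350 nM and compound 2 (`CN1CCN(CCCCCCn2c3c(c4ccccc42)C(=O)c2c[n+]([O-])c4ccccc4c2C3=O)CC1`) gives 630 nM, so compound 2 stands within the usual scatter of compound 1 and the two cannot be told apart on these numbers.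

The next structure, compound 3 (`O=C1c2c[n+]([O-])c3ccccc3c2C(=O)c2c1c1ccccc1n2Cc1cn(C[C@@H](O)CO)nn1`), is reached from compound 2 by a change at one place: 1-(2,3-dihydroxypropyl)-1H-1,2,3-triazol-4-yl in place of 5-(4-methylpiperazin-1-yl)pentyl on a saturated chain carbon bound to an aromatic nitrogen. In words, 1-(2,3-dihydroxypropyl)-1H-1,2,3-triazol-4-yl replaces 5-(4-methylpiperazin-1-yl)pentyl on a saturated chain carbon bound to an aromatic nitrogen.

For the measured compounds named here, only one measured step bears on this: a 1.8-fold higher number from compound 1 to compound 2 (0.26 log units; within the scatter). It exchanged the same two groups in the opposite direction, and its size lies within the scatter. Compound 3 does differ from compound 1 in how its defined stereocentre is set, and no measurement here tests that difference.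

In this assay, no step beyond the scatter is therefore expected, and the estimated step is a 1.7-fold lower number from compound 2 to compound 3 (0.22 log units; within the scatter). For compound 3 the expected value is 380 nM, with an estimated range from 170 nM to 850 nM.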

Compound 3, half-maximal inhibitory concentration: 140 nM
For compound 3 the middle estimate is 2.7-fold (0.43 log units) above the measured one; measured number below the stated range.
By their numbers in this assay, from the lowest: compound 3; then compounds 1 and 2 (each within the scatter of the next).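

In this assay, the place on a saturated chain carbon bound to an aromatic nitrogen now shows a step beyond the scatter: a 4.5-fold lower number from compound 2 to compound 3 (0.65 log units; beyond the scatter), when 1-(2,3-dihydroxypropyl)-1H-1,2,3-triazol-4-yl replaces 5-(4-methylpiperazin-1-yl)pentyl. The same two groups, with the stereocentre drawn the other way in compound 1, gave only a step within the scatter, so what this exchange delivers here depends on how that stereocentre is set. The configuration itself carries a step beyond the scatter, a 2.5-fold lower number from compound 1 to compound 3 (0.40 log units; beyond the scatter), and this step can be assigned to the stereocentre alone because nothing else separates the pair: the fact that compounds 1 and 3 differ only in the configuration as drawn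

Still open, as far as these compounds go, is which part of the entering group matters, the triazole ring or the two hydroxyl groups; a triazole bearing a plain propyl chain, or one bearing an amine in place of the hydroxyl groups, would help to separate the two. Also open, from the compounds shown here alone, is whether the preference for the R configuration holds on cell lines other than this one, or with a longer chain between the triazole and the hydroxyl groups.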